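A few compounds are considered here, and "the series" means these few. Any claim that something is new, unique, unknown or untested is made for them only; others in the source may bear on it.

Three compounds have been measured in a functional assay on MCF7 cells (Homo sapiens) for antiproliferative activity, read by MTT assay, with a stated time of 24 h; a lower number here means a stronger inhibitor, a higher number a weaker inhibitor:

compound 1 `Cc1ccc(C)c(S(=O)(=O)n2c(-c3cn(-c4ccccc4)nc3-c3ccc(F)cc3)nc3ccccc32)c1`, 430 nM
compound 2 `O=[N+]([O-])c1ccc(S(=O)(=O)n2c(-c3cn(-c4ccccc4)nc3-c3ccc(F)cc3)nc3ccccc32)cc1`, 1370 nM
compound 3 `Cc1ccc(C)c(S(=O)(=O)n2c(-c3cn(-c4ccccc4)nc3-c3ccc(C(F)(F)F)cc3)nc3ccccc32)c1`, 170 nM

Compound 1 and compound 2 share one core and differ in 4-nitrophenyl in place of 2,5-dimethylphenyl on a sulfonyl sulfur. That change made a 3.2-fold higher number from compound 1 to compound 2 (0.50 log units; beyond the scatter). Compound 3 differs from compound 1 in trifluoromethyl in place of fluoro on an aromatic carbon, and that change made a 2.5-fold lower number from compound 1 to compound 3 (0.40 log units; beyond the scatter), leaving compound 3 with the lowest number of the three.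

Compound 4 `O=[N+]([O-])c1ccc(S(=O)(=O)n2c(-c3cn(-c4ccccc4)nc3-c3ccc(C(F)(F)F)cc3)nc3ccccc32)cc1` is not yet measured. It differs from compound 3 in 4-nitrophenyl in place of 2,5-dimethylphenyl on a sulfonyl sulfur, which is the same change at the same place as from compound 1 to compound 2, carried out on the core of compound 3. A step of similar size is expected, a 3.2-fold higher number from compound 3 to compound 4 (0.50 log units; beyond the scatter). Among the compounds with values here, this rests only on a 3.2-fold higher number from compound 1 to compound 2 (0.50 log units; beyond the scatter), the single measured example of the change. Compound 4 is therefore estimated at 540 nM, most likely between 250 nM and 1200 nM.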

Compound 4, half-maximal inhibitory concentration: 1130 nM
For compound 4 the middle estimate is 2.1-fold (0.32 log units) below the measured one, and the stated range covers the measured number.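

Placing 4-nitrophenyl in place of 2,5-dimethylphenyl on the sulfonyl sulfur of the trifluoromethyl core gave a 6.6-fold higher number from compound 3 to compound 4 (0.82 log units; beyond the scatter), so the number rose on both cores, and the two steps do not differ beyond what repeat measurements would allow: the same change on two cores in this assay, a 3.2-fold higher number (0.50 log units; beyond the scatter) from compound 1 to compound 2 and a 6.6-fold higher number (0.82 log units; beyond the scatter) from compound 3 to compound 4, 2.1-fold (0.32 log units) apart, within the scatter of two such steps. Trifluoromethyl in place of fluoro, now on the 4-nitrophenyl core, gave a 1.2-fold lower number from compound 2 to compound 4 (0.08 log units; within the scatter), and this step too cannot be told apart from its earlier counterpart: the same change on two cores in this assay, a 2.5-fold lower number (0.40 log units; beyond the scatter) from compound 1 to compound 3 and a 1.2-fold lower number (0.08 log units; within the scatter) from compound 2 to compound 4, 2.1-fold (0.32 log units) apart, within the scatter of two such steps. Within the data shown here, with only two cores for each change, this does not show that either step has a fixed size or that it would carry over to a further core.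

The compounds shown leave open what a phenyl ring carrying an amine would do on the sulfonyl sulfur. They also leave open what chloro or methoxy would do in place of trifluoromethyl.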